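Moving the Nitrile Around the Sulfonyl-Linked Ring

The compounds below may be only part of what the source reports. "The series", "measured", "known", "first", "only" and "open" are said of these compounds alone.

Measured so far:
compound 1 `CC(O)(C(=O)Nc1ccc(S(=O)(=O)c2cccc(F)c2)cc1)C(F)(F)F`: 3400 nM
compound 2 `CC(O)(C(=O)Nc1ccc(S(=O)(=O)c2ccccc2C#N)cc1)C(F)(F)F`: 1100 nM

In a functional assay (Cavia porcellus) with sulfonylurea receptors; K-ATP channels (Homo sapiens) as the target (a higher number here means a weaker inhibitor, a lower number a stronger inhibitor), compound 2 gives 1100 nM, the lowest of the two numbers. Its nearest neighbour is compound 1 with 3400 nM. Among the compounds with values here, the single measured step is a 3.1-fold lower number from compound 1 to compound 2 (0.49 log units; beyond the scatter).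

Compound 3 `CC(O)(C(=O)Nc1ccc(S(=O)(=O)c2ccc(C#N)cc2)cc1)C(F)(F)F` carries 4-cyanophenyl in place of 2-cyanophenyl on a sulfonyl sulfur. Within the data shown here, the only measured step swapped one group for another as well as its place, so it bears only loosely on this change, and no measured pair separates the two cyanophenyl arrangements. The step from compound 2 to compound 3 is therefore expected to stay within the scatter, a 1.4-fold higher number from compound 2 to compound 3 (0.13 log units; within the scatter). Compound 3 is estimated at 1500 nM, between 500 nM and 5000 nM.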

Compound 3, half-maximal inhibitory concentration: > 30000 nM
Compound 3 gave a limit, no number; the forecaster's own chance of this, stated with the estimate: 5%; middle value at least 20-fold (1.30 log units) away from the limit.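

In this assay compound 3 gives > 30000 nM, which is a limit of the assay and not a number. With the same atoms joined differently, 4-cyanophenyl in place of 2-cyanophenyl on the sulfonyl sulfur gives an at least 27-fold higher number from compound 2 to compound 3 (1.43 log units; beyond the scatter), so where the nitrile sits on this ring matters greatly. Compared with the 3-fluorophenyl ring, the result is an at least 8.8-fold higher number from compound 1 to compound 3 (0.94 log units; beyond the scatter), so a nitrile on this ring does not by itself bring the lower number of compound 2.

As far as these compounds go, whether an aminophenyl or a methoxyphenyl group on the sulfonyl sulfur would read closer to compound 2 or to compound 3 stays open.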